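Aryl variation on the enone chain of the shared core

The compounds below may be only part of what the source reports. "The series", "measured", "known", "first", "only" and "open" are said of these compounds alone.

Compound 1 `O=C(/C=C/c1cccc2ccccc12)c1cccc(NC(=O)c2cc(-c3ccncc3)n[nH]2)c1` gives 72100 nM in a functional assay, read by spectrophotometry, tested at 100 uM (on this read-out higher numbers stand for weaker inhibition and lower numbers for stronger inhibition), the highest of the three numbers measured. Compound 2 `CN(C)c1ccc(/C=C/C(=O)c2cccc(NC(=O)c3cc(-c4ccncc4)n[nH]3)c2)cc1` gives 60900 nM and compound 3 `COc1cc(/C=C/C(=O)c2cccc(NC(=O)c3cc(-c4ccncc4)n[nH]3)c2)cc(OC)c1OC` gives 52900 nM in this assay; the steps of a 1.2-fold lower number from compound 1 to compound 2 (0.07 log units; within the scatter) and a 1.4-fold lower number from compound 1 to compound 3 (0.13 log units; within the scatter) both stay within the scatter, as does a 1.2-fold lower number from compound 2 to compound 3 (0.06 log units; within the scatter). Compound 4 `O=C(/C=C/c1ccc(Cl)cc1Cl)c1cccc(NC(=O)c2cc(-c3ccncc3)n[nH]2)c1` carries the change (2,4-dichlorophenyl in place of naphthalen-1-yl on a double-bonded chain carbon bound to a double-bonded chain carbon). All three measured steps exchange the aryl group at this same place, and none moved the number beyond the scatter, so no step beyond the scatter is expected here either. Compound 4 is therefore estimated at 65000 nM in this assay, with a range of 30000 nM to 140000 nM, which is an expected step of a 1.1-fold lower number from compound 1 to compound 4 (0.05 log units; within the scatter).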

Compound 4, half-maximal inhibitory concentration: 80900 nM
For compound 4 the middle estimate is 1.2-fold (0.10 log units) below the measured one, within the range that was stated.
By their numbers in this assay, from the lowest: compounds 3, 2, 1 and 4 (each within the scatter of the next).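

With 2,4-dichlorophenyl at this place, on a double-bonded chain carbon bound to a double-bonded chain carbon, all three new steps in this assay stay within the scatter: a 1.1-fold higher number from compound 1 to compound 4 (0.05 log units; within the scatter), a 1.3-fold higher number from compound 2 to compound 4 (0.12 log units; within the scatter) and a 1.5-fold higher number from compound 3 to compound 4 (0.18 log units; within the scatter). The exchange of the two aromatic rings of naphthalen-1-yl for the one ring of a chlorine-bearing aryl group therefore gives no resolved change. No measurement available here bears on the reason for this result.

Still open, going by these compounds, is whether a non-aromatic group at this place, such as an amine or a carboxylic acid, would give a step beyond the scatter.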